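Fluorophenyl for methyl across two cores: cytotoxicity notes

The source may hold more compounds than are shown below. What is called first, only, known or untested is meant among the compounds shown, and "the series" means these compounds.

Compound 1 `COc1cc(COCc2cn(Cc3cc(C)cnc3Cl)nn2)cc(OC)c1OC` carries a methyl on its core, and compound 3 `COc1cc(COCc2cn(Cc3cc(-c4ccc(F)cc4)cnc3Cl)nn2)cc(OC)c1OC` carries a 4-fluorophenyl at that place. In a functional assay on HeLa cells (Homo sapiens) for cytotoxicity, read by MTT assay, with a stated time of 48 h (on this read-out higher numbers stand for weaker inhibition and lower numbers for stronger inhibition), compound 1 gives 264000 nM, and compound 3 gives 49600 nM. The change 4-fluorophenyl in place of methyl on an aromatic carbon made the step of a 5.3-fold lower number from compound 1 to compound 3 (0.73 log units; beyond the scatter). Compound 2 `COc1cc(-c2cc(COCc3cn(Cc4cc(C)cnc4Cl)nn3)on2)cc(OC)c1OC` rests on a second core; how that core differs from the core of compound 1 is not broken down here. In this assay compound 2 gives 57700 nM, within the scatter of compound 3. Compound 4 `COc1cc(-c2cc(COCc3cn(Cc4cc(-c5ccc(F)cc5)cnc4Cl)nn3)on2)cc(OC)c1OC` is compound 2 with the same change, (4-fluorophenyl in place of methyl on an aromatic carbon), at the same place. Within the data shown here, the expected step is a 3.8-fold lower number from compound 2 to compound 4 (0.59 log units; beyond the scatter), somewhat below a 5.3-fold lower number from compound 1 to compound 3 (0.73 log units; beyond the scatter), since only that one instance of the change is measured. In this assay compound 4 is expected near 15000 nM, between 5000 nM and 45000 nM.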

Compound 4, half-maximal inhibitory concentration: 37300 nM
Beside the measured number, compound 4's estimate is 2.5-fold (0.40 log units) below it; measured number inside the range.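

Carried to the core of compound 2, 4-fluorophenyl in place of methyl on an aromatic carbon gives a 1.5-fold lower number from compound 2 to compound 4 (0.19 log units; within the scatter) in this assay. The step seen on the core of compound 1 therefore does not carry over at the same size to this second core: the same change on two cores in this assay, a 5.3-fold lower number (0.73 log units; beyond the scatter) from compound 1 to compound 3 and a 1.5-fold lower number (0.19 log units; within the scatter) from compound 2 to compound 4, 3.4-fold (0.54 log units) apart, beyond the scatter of two such steps

These two pairs show that the size of the step differs between these two cores, but they do not show why it differs or how the change would behave on any further core.

Open, as far as these compounds go, is whether the same gap between the cores appears with other groups at this place, such as an unsubstituted phenyl, a primary amine or a carboxylic acid. Also open, from the compounds shown here alone, is whether a longer alkyl chain in place of methyl would separate the two cores in the same way.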